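This account rests on a few compounds, and the source may have more. Where it says the series, first, only, none or still open, it means among the compounds named here.

Measured compounds in a functional assay on P388 cells (Mus musculus) for cytotoxicity, read by MTT assay, with a stated time of 72 h; on this read-out higher numbers stand for weaker inhibition and lower numbers for stronger inhibition:
compound 1 `Cc1c(/N=C/c2ccc(N(C)C)cc2)c(=O)n(-c2ccccc2)n1C` gives 468000000 nM
compound 2 `Cc1c(/N=C/c2cccc(O)c2)c(=O)n(-c2ccccc2)n1C` gives 437000000 nM
compound 3 `Cc1c(/N=C/c2cccc([N+](=O)[O-])c2)c(=O)n(-c2ccccc2)n1C` gives 490000000 nM

In this assay compound 2 shows the lowest of the three numbers, but its gaps to compound 1 and to compound 3 both lie within the scatter, so no order among the three can be drawn. Among the compounds with values here, the one measured step that varies the aromatic substituent, a 1.1-fold higher number from compound 2 to compound 3 (0.05 log units; within the scatter), stays within the scatter as well.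

Compound 4 `Cc1c(/N=C/c2ccc(Cl)cc2Cl)c(=O)n(-c2ccccc2)n1C` differs from compound 2 by 2,4-dichlorophenyl in place of 3-hydroxyphenyl on a carbon with a double bond to nitrogen. Within the data shown here, the single comparable step gives no sign that an exchange on this ring moves this assay, so the step of a 1.0-fold higher number from compound 2 to compound 4 (0.01 log units; within the scatter) is expected to remain within the scatter. Compound 4 is therefore estimated at 450000000 nM in this assay, with a range from 200000000 nM to 1000000000 nM.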

Compound 4, half-maximal inhibitory concentration: 363000000 nM
Beside the measured number, compound 4's estimate is 1.2-fold (0.09 log units) above it; measured number inside the range.
By their numbers in this assay, from the lowest: compounds 4, 2, 1 and 3 (each within the scatter of the next).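

In this assay, 2,4-dichlorophenyl in place of 3-hydroxyphenyl on the carbon with a double bond to nitrogen gives a 1.2-fold lower number from compound 2 to compound 4 (0.08 log units; within the scatter) and so stays within the scatter. The flat picture now holds for a change of two substituents on this ring, including loss of the hydrogen-bond donor and acceptor counted on 3-hydroxyphenyl. No evidence on the cause is at hand. Open, going by these compounds, is whether a carboxylic acid or an amine on this ring, or a longer alkyl chain in its place, would move the number.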